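The compounds below may be only part of what the source reports. "The series", "measured", "known", "first", "only" and "open" are said of these compounds alone.

Measured in an assay on CHO cells for displacement of a labelled ligand from adenosine receptor A3 (Homo sapiens), read by scintillation counting, with a stated time of 120 min, tested at 10 uM; a lower number here means less inhibition, a higher number more inhibition at the concentration tested (going by the name of the read-out):

compound 1 `Nc1scc(CN2CCN(c3ccc(F)cc3Cl)CC2)c1C(=O)c1ccc(Cl)cc1` gives 0%
compound 2 `Nc1scc(CN2CCN(c3ccc(Cl)cc3F)CC2)c1C(=O)c1ccc(Cl)cc1` gives 1%
compound 3 `COc1ccc(N2CCN(Cc3csc(N)c3C(=O)c3ccc(Cl)cc3)CC2)cc1` gives 0%

Compound 3 stands level with compound 1 at the digits shown, and the two are together the lowest of the three numbers; compound 2 lies nearest above it, but a number 1 percentage points lower from compound 2 to compound 3 (within the scatter) and no change at the digits printed from compound 1 to compound 3 (within the scatter) are both within the scatter, as is a number 1 percentage points higher from compound 1 to compound 2 (within the scatter). Compound 4 `Nc1scc(CN2CCN(c3ccc(Cl)c(C(F)(F)F)c3)CC2)c1C(=O)c1ccc(Cl)cc1` has not yet been measured. It differs from compound 3 by 4-chloro-3-(trifluoromethyl)phenyl in place of 4-methoxyphenyl on an amine nitrogen in a ring. Going by the values given here, the steps that bear on this are the two exchanges of the aryl group on the ring nitrogen leading to compound 3, neither of which moved the number beyond the scatter. Compound 4 is therefore expected to show no step beyond the scatter, a number 1 percentage points higher from compound 3 to compound 4 (within the scatter). Compound 4 is estimated at 1%, within a range from 0% to 10%.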

Compound 4, a percentage reported as inhibition, at one concentration (the size of the read-out at that concentration, not a potency): 3%
For compound 4 the middle estimate is 2 percentage points below the measured one; the measured number falls inside the stated range.
By their numbers in this assay, from the lowest: compounds 1, 3, 2 and 4 (each within the scatter of the next).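

In this assay, 4-chloro-3-(trifluoromethyl)phenyl on the amine nitrogen in the ring gives a number 3 percentage points higher from compound 3 to compound 4 (within the scatter), a number 2 percentage points higher from compound 2 to compound 4 (within the scatter) and a number 3 percentage points higher from compound 1 to compound 4 (within the scatter). This exchange removes the hydrogen-bond acceptor of 4-methoxyphenyl and brings more heavy atoms, yet all four aryl groups at this position now lie within the scatter of one another. Nothing measured here accounts for this.

The compounds shown leave open whether a non-aryl group on this nitrogen, such as a carboxylic acid or a longer chain, would give a different number. They also leave open what a change elsewhere on the shared core would do.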